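A Hydroxyl on the Sulfonyl Chain of Compound 2

The compounds below may be only part of what the source reports. "The series", "measured", "known", "first", "only" and "open" are said of these compounds alone.

Compound 1 `CCCc1cnc(N2CCC(C3Cc4cc(C5=CCN(S(=O)(=O)CCC)CC5)ccc4O3)CC2)nc1`: 82 nM
Compound 2 `CCCc1cnc(N2CCC(C3Cc4cc(C5=CCN(S(=O)(=O)CCC)CC5)cc(F)c4O3)CC2)nc1`: 62 nM
Compound 3 `CCCc1cnc(N2CCC(C3Cc4c(F)c(C5=CCN(S(=O)(=O)CCC)CC5)cc(F)c4O3)CC2)nc1`: 2 nM

Of the compounds shown here, three have been measured in a functional assay on HEK293 cells for agonist activity at Glucose-dependent insulinotropic receptor (Homo sapiens), read by cAMP accumulation, with a stated time of 60 min; a higher number here means that more compound is needed for the effect, a lower number that less compound is needed. Compound 2 gives 62 nM and stands second highest of the three numbers. Its nearest neighbour is compound 1, and the step of a 1.3-fold lower number from compound 1 to compound 2 (0.12 log units; within the scatter) lies within the scatter. Its furthest neighbour is compound 3, and the step of a 31-fold lower number from compound 2 to compound 3 (1.49 log units; beyond the scatter) is large and well beyond the scatter.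

Compound 4 `CCCc1cnc(N2CCC(C3Cc4cc(C5=CCN(S(=O)(=O)CCCO)CC5)cc(F)c4O3)CC2)nc1` is not yet measured. It differs from compound 2 by hydroxy in place of hydrogen on a saturated chain carbon, three bonds along the chain from a sulfonyl sulfur. Among the compounds with values here, both measured steps concern fluoro in place of hydrogen on an aromatic carbon; neither of them touches the chain on the sulfonyl sulfur, so no measured step bears directly on this change. The expectation therefore rests on compound 2 alone, and no step beyond the scatter is expected in this assay, a 1.0-fold higher number from compound 2 to compound 4 (0.02 log units; within the scatter). Compound 4 is expected to give about 65 nM, within a range from 25 nM to 160 nM.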

Compound 4, half-maximal effective concentration: 122 nM
Compound 4: middle estimate off by 1.9-fold (0.27 log units), on the low side, within the range that was stated.
By their numbers in this assay, from the lowest: compound 3; then compounds 2, 1 and 4 (each within the scatter of the next).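

In this assay, hydroxy in place of hydrogen on a saturated chain carbon, three bonds along the chain from a sulfonyl sulfur, gives a 2.0-fold higher number from compound 2 to compound 4 (0.29 log units; within the scatter). Within the data shown here, this is the first reading at the chain on the sulfonyl sulfur, since the earlier steps concerned only fluoro on aromatic carbons, and it shows that the change from propyl to 3-hydroxypropyl on compound 2 stays within the scatter, unlike the large step of a 31-fold lower number from compound 2 to compound 3 (1.49 log units; beyond the scatter).

From the compounds shown here alone, it remains open whether a carboxylic acid, an amine or a longer chain at this position would also stay within the scatter. Also open, going by these compounds, is whether the 3-hydroxypropyl chain would read the same on compound 3, which gives 2 nM. Nothing available offers an explanation for the reading at this position.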